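Removing the tert-butyl from the aryl on the triazole

The source may report more compounds than this note shows. Statements on the series, on what has been measured and on what is new or still open speak of the compounds shown alone.

Three compounds of this series have numbers in a functional assay on MDA-MB-231 cells (Homo sapiens) for antiproliferative activity, read by MTT assay, with a stated time of 24 h; a higher number here means a weaker inhibitor, a lower number a stronger inhibitor. Compound 1 `CC(C)(C)c1ccc(-c2cn(C/C=C3\OC(=O)C(OCc4ccccc4)=C3OCc3ccccc3)nn2)cc1` gives 51200 nM in this assay, the lowest of the two numbers shown. Compound 2 `Cc1ccc(-c2cn(CCC3(O)NC(=O)C(OCc4ccccc4)=C3OCc3ccccc3)nn2)cc1` gives 82200 nM in this assay, a value within the scatter of compound 1, so no order between the two can be read. Compound 3 `CCCCCCCCN1C(=O)C(OCc2ccccc2)=C(OCc2ccccc2)C1(O)CCn1cc(-c2ccccn2)nn1` reaches only a limit of this assay, > 100000 nM; the limit of > 100000 nM in this assay, at which 1 of the 3 values shown sits, is the edge of the assay and not a number. For the measured compounds named here, no pair of measured compounds differs in one place, so no measured step is available.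

Compound 4 `O=C1O/C(=C\Cn2cc(-c3ccccc3)nn2)C(OCc2ccccc2)=C1OCc1ccccc1` is the next entry. Relative to compound 1 the change is hydrogen in place of tert-butyl on an aromatic carbon. The change is small by size, and no evidence in the series connects this group with the readout. The step from compound 1 to compound 4 is expected to be no larger than the scatter, with a slight lean toward a higher number, a 1.4-fold higher number from compound 1 to compound 4 (0.14 log units; within the scatter). Compound 4 is accordingly estimated at 70000 nM in this assay, within 30000 nM to 160000 nM, with a real chance that only a limit is reported.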

Compound 4, half-maximal inhibitory concentration: 44000 nM
Beside the measured number, compound 4's estimate is 1.6-fold (0.20 log units) above it; measured number inside the range.
By their numbers in this assay, from the lowest: compounds 4, 1 and 2 (each within the scatter of the next). At a limit, above all of these: compound 3.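

In this assay, the series now has its first measured one-place step, a 1.2-fold lower number from compound 1 to compound 4 (0.07 log units; within the scatter), and it lies within the scatter. Replacing 4-(tert-butyl)phenyl with phenyl therefore produces no readable shift, which shows that on this core the tert-butyl, at this position para to a large group, is not required for the number seen with compound 1. Nothing measured here accounts for the size of this step.

Going by these compounds, on this core, the comparison at this position covers only tert-butyl and hydrogen, so how an amine, a carboxylic acid or a methoxy group would read there remains open. Also open, on these data alone, is whether any group at this position can move the number beyond the scatter, or whether a change elsewhere in the core would do so.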